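Swapping methyl for chloro on an indole-bearing diterpene core

A few compounds are considered here, and "the series" means these few. Any claim that something is new, unique, unknown or untested is made for them only; others in the source may bear on it.

Measured compounds:
- Compound 1 `COC(=O)[C@@]1(C)CCC=C2[C@@H]1CC[C@@H](C)[C@]2(C)Cc1c[nH]c2c(Cl)cccc12`: 31000 nM
- Compound 2 `COC(=O)[C@@]1(C)CCC=C2[C@@H]1CC[C@@H](C)[C@]2(C)Cc1c(C)[nH]c2ccccc12`: 19000 nM
- Compound 3 `COC(=O)[C@@]1(C)CCC=C2[C@@H]1CC[C@@H](C)[C@]2(C)Cc1c(C)[nH]c2c(C)cccc12`: 21000 nM

In a functional assay on WiDr cells (Homo sapiens) for inhibition, read by sulforhodamine B assay, with a stated time of 48 h (on this read-out higher numbers stand for weaker inhibition of growth and lower numbers for stronger inhibition of growth), compound 3 gives 21000 nM, the second highest of the three numbers; compound 2 sits nearest, and compound 1 furthest, both within the scatter. Compound 4 `COC(=O)[C@@]1(C)CCC=C2[C@@H]1CC[C@@H](C)[C@]2(C)Cc1c(C)[nH]c2c(Cl)cccc12` differs from compound 3 by one change: chloro in place of methyl on an aromatic carbon, placed on an aromatic carbon of a six-membered aromatic ring of carbon only, part of a fused system of two rings. Going by the values given here, only one measured step touches this position, a 1.1-fold higher number from compound 2 to compound 3 (0.04 log units; within the scatter), and it stayed within the scatter. Among the compounds with values here, no measured step exchanges methyl for chloro. A step of a 1.2-fold higher number from compound 3 to compound 4 (0.08 log units; within the scatter) is therefore expected, with no clear direction. Compound 4 is estimated at 25000 nM, between 12000 nM and 50000 nM.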

Compound 4, concentration for 50% growth inhibition: 29000 nM
Compound 4: the middle estimate sits 1.2-fold (0.06 log units) below what was measured; the measured number falls inside the stated range.
By their numbers in this assay, from the lowest: compounds 2, 3, 4 and 1 (each within the scatter of the next).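

In this assay, hydrogen, methyl and chloro at this position on the six-membered aromatic ring cannot be told apart: chloro for methyl gives a 1.4-fold higher number from compound 3 to compound 4 (0.14 log units; within the scatter), and chloro for hydrogen gives a 1.5-fold higher number from compound 2 to compound 4 (0.18 log units; within the scatter). Adding a methyl elsewhere on an aromatic carbon of the shared core also changes little, with a 1.1-fold lower number from compound 1 to compound 4 (0.03 log units; within the scatter). Methyl in place of hydrogen reads alike in both settings: the same change on two cores in this assay, a 1.1-fold higher number (0.04 log units; within the scatter) from compound 2 to compound 3 and a 1.1-fold lower number (0.03 log units; within the scatter) from compound 1 to compound 4, 1.2-fold (0.07 log units) apart, within the scatter of two such steps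

From the compounds shown here alone, whether an amine or a carboxylic acid at this position would move the number beyond the scatter stays open.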